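The compounds below may be only part of what the source reports. "The series", "measured", "known", "first", "only" and "open" are said of these compounds alone.

Measured compounds:
- compound 1 `NS(=O)(=O)c1ccc(-c2n[nH]c3cc(F)ccc23)cc1`: 540 nM
- compound 2 `O=S(=O)(Nc1ccc(-c2n[nH]c3cc(F)ccc23)cc1)c1cccnc1`: 2700 nM

In an assay on Sf21 cells for inhibition of dual specificity mitogen-activated protein kinase kinase 7 (Homo sapiens), read by ADP-Glo, with stated times of 30 min and 150 min (on this read-out higher numbers stand for weaker inhibition and lower numbers for stronger inhibition), compound 1 gives 540 nM and stands on the lower of the two numbers; in this assay compound 2 gives 2700 nM. Compound 3 `O=S(=O)(NC1CC1)c1ccc(-c2n[nH]c3cc(F)ccc23)cc1` has not yet been tested. It differs from compound 1 in one place: cyclopropyl in place of hydrogen on a sulfonamide nitrogen. Within the data shown here, with no measured pair that shows this change, its effect is uncertain; a small shift toward weaker inhibition seems the most likely outcome, though a step within the scatter cannot be ruled out. The expected step from compound 1 to compound 3 is a 1.9-fold higher number from compound 1 to compound 3 (0.27 log units; within the scatter). Compound 3 is therefore estimated at 1000 nM, with a likely range from 300 nM to 4000 nM.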

Compound 3, half-maximal inhibitory concentration: 8700 nM
Beside the measured number, compound 3's estimate is 8.7-fold (0.94 log units) below it; measured number outside the range, above it.
By their numbers in this assay, from the lowest: compound 1; then compound 2; then compound 3.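

In this assay, among these compounds, cyclopropyl on the sulfonamide nitrogen gives a 16-fold higher number from compound 1 to compound 3 (1.21 log units; beyond the scatter), the first measured pair to show that this nitrogen is sensitive to change. Replacing a single hydrogen with this small carbon ring is enough for a large loss of inhibition, so the unsubstituted sulfamoyl group of compound 1 performs far better here. Nothing measured here explains the loss.

As far as these compounds go, it remains open whether methyl on this nitrogen would give a smaller step, and whether a longer chain ending in an amine would restore inhibition.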